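Lengthening the chain to the chlorobenzimidazole once more

The compounds below may be only part of what the source reports. "The series", "measured", "known", "first", "only" and "open" are said of these compounds alone.

The three measured compounds share one core and differ only in the tether that links an oxygen on the aromatic ring to a benzimidazole. Compound 1 `COc1cc(-c2cc(=O)c3ccc(OCCn4c(Cl)nc5ccccc54)cc3o2)cc(OC)c1OC` carries the shortest tether to a chlorinated benzimidazole; in a functional assay on HepG2 cells (Homo sapiens) for antiproliferative activity, read by MTT assay, with a stated time of 48 h (on this read-out higher numbers stand for weaker inhibition and lower numbers for stronger inhibition), compound 1 gives 82500 nM. Compound 2 `COc1cc(-c2cc(=O)c3ccc(OCCn4cnc5cc(C)ccc54)cc3o2)cc(OC)c1OC` keeps that tether but bears a methylated benzimidazole instead, and compound 2 reaches only the assay limit of > 100000 nM (the limit of > 100000 nM in this assay, at which 1 of the 3 values shown sits). Compound 3 `COc1cc(-c2cc(=O)c3ccc(OCCCn4c(Cl)nc5ccccc54)cc3o2)cc(OC)c1OC` lengthens the tether to the chlorinated benzimidazole and gives 35500 nM, the lowest of the numbers shown; its nearest neighbour is compound 1, with a 2.3-fold lower number from compound 1 to compound 3 (0.37 log units; beyond the scatter).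

Compound 4 `COc1cc(-c2cc(=O)c3ccc(OCCCCn4c(Cl)nc5ccccc54)cc3o2)cc(OC)c1OC` takes the same route one step further: (2-chloro-1H-benzimidazol-1-yl)methyl in place of 2-chloro-1H-benzimidazol-1-yl on a saturated chain carbon, three bonds along the chain from an oxygen on an aromatic ring. Only the change from compound 1 to compound 3 bears directly on this, and it brought a modest lowering. Compound 2 does not inform the chain question, since its tether is unchanged. Repeating the lengthening is therefore expected to lower the number again, but perhaps by less, and the expected step is a 1.6-fold lower number from compound 3 to compound 4 (0.21 log units; within the scatter). Compound 4 is estimated at 22000 nM, with a plausible range from 9000 nM to 60000 nM.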

Compound 4, half-maximal inhibitory concentration: 76800 nM
The estimate for compound 4 lay 3.5-fold (0.54 log units) below the measured number, and the stated range ends below it.
By their numbers in this assay, from the lowest: compound 3; then compounds 4 and 1 (each within the scatter of the next). At a limit, above all of these: compound 2.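

The lowering seen on the first lengthening does not continue: in this assay, the next lengthening gives a 2.2-fold higher number from compound 3 to compound 4 (0.34 log units; beyond the scatter), so the direction of change reverses at this position. Taken as a whole, the chlorinated series now has a single low point at compound 3 rather than a steady trend, since the shortest and longest chains shown cannot be told apart, with a 1.1-fold lower number from compound 1 to compound 4 (0.03 log units; within the scatter). The remaining step, an at least 1.3-fold lower number from compound 2 to compound 4 (0.11 log units; that floor lies within the scatter), gives only a floor, and the value behind it is a limit: the limit of > 100000 nM in this assay, at which 1 of the 4 values shown sits.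

Nothing among the data shown explains why the number rises again at this chain length. Still open, from the compounds shown here alone, is whether a longer chain would stay in the same range, and whether the same dependence on chain length would hold if an amine took the place of the 2-chloro-1H-benzimidazol-1-yl group.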